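Thiazolyl for fluorophenyl on the amine side chain

The source may hold more compounds than are shown below. What is called first, only, known or untested is meant among the compounds shown, and "the series" means these compounds.

Measured so far:
compound 1 `C=C1CC[C@@H]2[C@](C)(CO)[C@H](O)CC[C@@]2(C)[C@@H]1C/C=C1\C=COC1=O` — 2770 nM
compound 2 `C=C1CC[C@@H]2[C@](C)(CO)[C@H](O)CC[C@@]2(C)[C@@H]1C/C=C(/C(=O)O)[C@H](O)CO` — > 30000 nM
compound 3 `C=C1CC[C@@H]2[C@](C)(CNCc3ccc(F)cc3)[C@H](O)CC[C@@]2(C)[C@@H]1/C=C/C1=CCOC1=O` — 350 nM

In a functional assay on BMMC cells (Mus musculus, strain C57BL/6) for inhibition, with stated times of 5 days and 48 h (a higher number here means a weaker inhibitor, a lower number a stronger inhibitor), compound 1 gives 2770 nM. Compound 2 yields only a limit, (the limit of > 30000 nM in this assay, at which 1 of the 3 values shown sits), not a number. Compound 3 gives 350 nM, the lowest of the two numbers; compound 1 is its nearest neighbour, and that gap lies beyond the usual scatter.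

Compound 4 `C=C1CC[C@@H]2[C@](C)(CNCc3nccs3)[C@H](O)CC[C@@]2(C)[C@@H]1/C=C/C1=CCOC1=O` keeps the amine side chain of compound 3 and changes only its terminal ring: 1,3-thiazol-2-yl in place of 4-fluorophenyl on a saturated chain carbon bound to an amine nitrogen. Going by the values given here, with no comparable step measured, the step of a 1.6-fold higher number from compound 3 to compound 4 (0.20 log units; within the scatter) is expected to be small, close to the scatter, if anything a slight weakening. For compound 4 an estimate of 550 nM is expected, within 170 nM to 1800 nM.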

Compound 4, half-maximal inhibitory concentration: 700 nM
Beside the measured number, compound 4's estimate is 1.3-fold (0.10 log units) below it; the range from low to high includes it.
By their numbers in this assay, from the lowest: compounds 3 and 4 (each within the scatter of the next); then compound 1. At a limit, above all of these: compound 2.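

In this assay, the terminal ring on the amine side chain can be exchanged without a step beyond the scatter: a 2.0-fold higher number from compound 3 to compound 4 (0.30 log units; within the scatter). For this pair, the place on a saturated chain carbon bound to an amine nitrogen therefore accepts a five-membered aromatic ring with 2 hetero atoms as well as a six-membered ring of carbon only. Nothing available accounts for the step in terms of either ring. From the compounds shown here alone, whether a ring is needed here stays open, for instance against a simple methyl group on the same nitrogen. Going by these compounds, compound 1 and compound 3 differ in more than one place, so the share of the amine side chain in their gap also stays open.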